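A few compounds are considered here, and "the series" means these few. Any claim that something is new, unique, unknown or untested is made for them only; others in the source may bear on it.

Measured compounds in an ADME assay on Vero cells (Chlorocebus sabaeus) for cytotoxicity, read by MTT assay, with a stated time of 48 h; on this read-out higher numbers stand for weaker inhibition and lower numbers for stronger inhibition:
- compound 1 `CC(=O)NC1CCC(CN2CCN(c3cc(=O)c4cc(C(F)(F)F)cc([N+](=O)[O-])c4s3)CC2)CC1`; the value is a limit, > 64 ug/mL
- compound 2 `O=C(OC1CCC(CN2CCN(c3cc(=O)c4cc(C(F)(F)F)cc([N+](=O)[O-])c4s3)CC2)CC1)c1ccc(F)cc1`; the value is a limit, > 64 ug/mL
- compound 3 `O=C(OC1CCC(CN2CCN(c3cc(=O)c4cc(C(F)(F)F)cc([N+](=O)[O-])c4s3)CC2)CC1)c1ccncc1`; the value is a limit, > 64 ug/mL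

Among the measured compounds shown here, compound 1 stands only at a limit in this assay, and the two further values are limits as well, so no compound in the set can be placed above or below another. The steps that differ in one place are accordingly unreadable: a step that the two limits leave unreadable from compound 1 to compound 2, a step that the two limits leave unreadable from compound 1 to compound 3 and a step that the two limits leave unreadable from compound 2 to compound 3. All three values sit at the limit of > 64 ug/mL in this assay, at which 3 of the 3 values shown sit.

Compound 4 `O=C(OC1CCC(CN2CCN(c3cc(=O)c4cc(C(F)(F)F)cc([N+](=O)[O-])c4s3)CC2)CC1)c1ccccc1` is not yet measured. It differs from compound 1 as follows: benzoyloxy in place of acetamido on a saturated ring carbon. For the measured compounds named here, the steps that bear on it are the exchanges of acetamido for an aroyloxy group on the same saturated ring carbon, and both left the value at the limit. No readable step is available, and none beyond the scatter is expected; compound 4 is expected to remain at the limit, with an estimate of 120 ug/mL (range 60 ug/mL to 250 ug/mL). The estimated change is a step that the limit leaves unreadable from compound 1 to compound 4.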

Compound 4, half-maximal inhibitory concentration: > 64 ug/mL
Compound 4 was reported as a limit (the forecaster's own chance of this, stated with the estimate: 90%); the middle value is on the limit's open side.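

In this assay, among the compounds shown here, compound 4 gives the limit > 64 ug/mL and no step from compound 1, compound 2 or compound 3 to compound 4 can be read: the limit of > 64 ug/mL in this assay, at which 4 of the 4 values shown sit.

The compounds shown leave open whether any exchanged group changes the read-out, and where the actual value of any of the four compounds lies.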